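A few compounds are considered here, and "the series" means these few. Any claim that something is new, unique, unknown or untested is made for them only; others in the source may bear on it.

Compound 2 `COc1ccc(-c2csc(N3N=C(c4ccc(Br)cc4)CC3c3ccc4c(c3)OCCO4)n2)cc1` gives the lower of the two numbers measured in a functional assay on MCF7 cells (Homo sapiens) for antiproliferative activity, read by MTT assay, with a stated time of 48 h (a higher number here means a weaker inhibitor, a lower number a stronger inhibitor), namely 870 nM. Among the measured compounds shown here, the only comparison is compound 1 `COc1ccc(C2=NN(c3nc(-c4ccc(OC)cc4)cs3)C(c3ccc4c(c3)OCCO4)C2)cc1`, which in this assay gives 2730 nM; the exchange of methoxy for bromo on an aromatic carbon brings a 3.1-fold lower number from compound 1 to compound 2 (0.50 log units; beyond the scatter), a modest step that lies beyond the scatter.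

Compound 3 `COc1ccc(-c2csc(N3N=C(c4ccc(Cl)cc4)CC3c3ccc4c(c3)OCCO4)n2)cc1` is the next compound. It differs from compound 2 in one place: chloro in place of bromo on an aromatic carbon. For the measured compounds named here, the only step measured so far, from compound 1 to compound 2, changed the very same position, yet it swapped a group of different size and make-up, whereas the new change exchanges one single atom for another single atom. Going by the values given here, no measured pair shows what such a swap does here. Among the compounds with values here, since the single measured step at this position was itself only modest, the step from compound 2 to compound 3 in this assay is expected to be small, at most a slight rise in the number, and quite possibly within the scatter, expected as a 1.1-fold higher number from compound 2 to compound 3 (0.06 log units; within the scatter). Compound 3 is therefore estimated at 1000 nM in this assay, with a range from 450 nM to 2300 nM.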

Compound 3, half-maximal inhibitory concentration: 3030 nM
Compound 3: the middle estimate sits 3.0-fold (0.48 log units) below what was measured, and the stated range ends below it.
By their numbers in this assay, from the lowest: compound 2; then compounds 1 and 3 (each within the scatter of the next).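

In this assay, exchanging one halogen for another on this aromatic carbon is not a neutral edit: chloro in place of bromo gives a 3.5-fold higher number from compound 2 to compound 3 (0.54 log units; beyond the scatter), a modest step beyond the scatter that runs opposite to a 3.1-fold lower number from compound 1 to compound 2 (0.50 log units; beyond the scatter). The third compound also changes how that earlier step reads, since chloro in place of methoxy gives a 1.1-fold higher number from compound 1 to compound 3 (0.05 log units; within the scatter), which lies within the scatter, so the lower number of compound 2 belongs to bromo in this set and not to halogens as a group, with compound 3 going against any such wider rule. Nothing shown here gives a measured property that could explain why bromo stands apart from chloro and methoxy.

As far as these compounds go, it remains open whether fluoro or iodo at the same place would fall with bromo or with chloro, and what a quite different group there, such as an amine, a carboxylic acid or a longer alkyl chain, would do to the number. Also open, from the compounds shown here alone, is whether the gap between bromo and chloro would persist if another part of the shared core were changed.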